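One Methyl-Removal Change, Tested Twice

The compounds below may be only part of what the source reports. "The series", "measured", "known", "first", "only" and "open" are said of these compounds alone.

Compound 1 `COc1ccc(Oc2ccc(C(C)C)cc2-c2ccsc2S(=O)(=O)NCCNC(=S)Nc2ccc([N+](=O)[O-])cc2)cc1OC` gives 11900 nM in a functional assay on HeLa cells (Homo sapiens) for inhibition, read by CCK-8 assay, with a stated time of 48 h; on this read-out lower numbers stand for stronger inhibition and higher numbers for weaker inhibition.
Compound 2 `CC(C)c1ccc(Oc2ccc(O)c(O)c2)c(-c2ccsc2S(=O)(=O)NCCNC(=S)Nc2ccc([N+](=O)[O-])cc2)c1` gives only a limit, > 20000 nM, in this assay.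
Compound 3 `COc1ccc(Oc2ccccc2-c2ccsc2S(=O)(=O)N2CCN(C(=O)Nc3ccc([N+](=O)[O-])cc3)CC2)cc1OC` gives only a limit, > 50000 nM, in this assay.

The change from compound 1 to compound 2 is 3,4-dihydroxyphenyl in place of 3,4-dimethoxyphenyl on an oxygen on an aromatic ring, and it made an at least 1.6-fold higher number from compound 1 to compound 2 (0.22 log units; that floor lies within the scatter). That step rests on (the limit of > 20000 nM in this assay, at which 1 of the 3 values shown sits), so its true size is not pinned down. The same change, (3,4-dihydroxyphenyl in place of 3,4-dimethoxyphenyl on an oxygen on an aromatic ring), turns compound 3 into compound 4 `O=C(Nc1ccc([N+](=O)[O-])cc1)N1CCN(S(=O)(=O)c2sccc2-c2ccccc2Oc2ccc(O)c(O)c2)CC1`, which is not yet measured. How the core of compound 1 differs from the core of compound 3 is not broken down here. Since compound 3 sits at the limit of > 50000 nM in this assay, at which 1 of the 3 values shown sits, the step from compound 3 to compound 4 is expected to be a step that the limit leaves unreadable from compound 3 to compound 4, beside the earlier one. Compound 4 is expected to give 80000 nM in this assay, most likely reported again only as a limit.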

Compound 4, half-maximal inhibitory concentration: > 20000 nM
Compound 4 ended at the assay's limit (the forecaster's own chance of this, stated with the estimate: 85%); the middle value lies beyond the limit too.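

In this assay compound 3 and compound 4 both give only limits, so the step between them cannot be read. The compounds shown leave open how far 3,4-dihydroxyphenyl in place of 3,4-dimethoxyphenyl truly shifts inhibition, on either core.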